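The source may report more compounds than this note shows. Statements on the series, on what has been measured and on what is new or still open speak of the compounds shown alone.

Measured compounds:
compound 1, `CCCO/N=C/c1c(N)ncnc1Oc1ccc2[nH]c(C)cc2c1F`, 30 nM
compound 2, `CO/N=C/c1c(N)ncnc1Oc1ccc2[nH]ccc2c1`, 3520 nM
compound 3, `COCCCO/N=C/c1c(N)ncnc1Oc1ccc2[nH]c(C)cc2c1F`, 438 nM

In a functional assay on HCT-116 cells (Homo sapiens) for antiproliferative activity (on this read-out higher numbers stand for weaker inhibition and lower numbers for stronger inhibition), compound 1 stands lowest of the three; compound 3 gives 438 nM and compound 2 gives 3520 nM, both well apart from it. Compound 4, `CNCCO/N=C/c1c(N)ncnc1Oc1ccc2[nH]c(C)cc2c1F`, has not yet been measured. It differs from compound 1 in one place: methylamino in place of methyl on a saturated chain carbon, two bonds along the chain from an oxygen on an unsaturated carbon.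

Among the compounds with values here, one measured step bears on this change. It is a 15-fold higher number from compound 1 to compound 3 (1.16 log units; beyond the scatter), where a chain carbon of the same side chain was substituted with a group carrying a hydrogen-bond acceptor. In compound 4 the chain carbon two bonds from the oxygen on the unsaturated carbon instead carries a group with one donor and one acceptor, so the precedent points the same way: a higher number in this assay is expected for compound 4, though the step is shorter by one bond and the group differs, so a smaller rise than in compound 3 seems as likely as an equal one.

The expected step is a 5.0-fold higher number from compound 1 to compound 4 (0.70 log units; beyond the scatter), and compound 4 is estimated at 150 nM, within 40 nM to 600 nM.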

Compound 4, half-maximal inhibitory concentration: 3010 nM
Beside the measured number, compound 4's estimate is 20-fold (1.30 log units) below it; measured number outside the range, above it.
By their numbers in this assay, from the lowest: compound 1; then compound 3; then compounds 4 and 2 (each within the scatter of the next).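

Placing methylamino on this chain carbon gives a 100-fold higher number from compound 1 to compound 4 (2.00 log units; beyond the scatter) in this assay, so this side chain position is highly sensitive to the change, and the rise seen with the methoxy-bearing chain of compound 3 is not its upper end. The two substituted chains are also not interchangeable: methylamino in place of methoxymethyl gives a 6.9-fold higher number from compound 3 to compound 4 (0.84 log units; beyond the scatter) and so separates two compounds that both stand well above compound 1. No available evidence accounts for the size of either step.

The compounds shown leave open whether a hydroxy group or a dimethylamino group on the same chain carbon would behave like methylamino or like methoxymethyl. They also leave open how a longer chain carrying the methylamino group would read in this assay.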